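A few compounds are considered here, and "the series" means these few. Any claim that something is new, unique, unknown or untested is made for them only; others in the source may bear on it.

For the measured compounds named here, compound 1 `O=C(C1CCOCC1)N1N=CCC1c1ccccc1` is the more polar of the two compounds measured so far. In a physicochemical assay for lipophilicity, read by HPLC, measured as chromatographic lipophilicity, at pH 7.4 (a lower number here means a more polar compound, a higher number a more lipophilic compound), compound 1 gives 3.1, while compound 2 `CC1=NN(C(=O)C(C)(C)C)[C@H](c2ccccc2)C1`, which carries a different carbon-only group on the same carbonyl carbon and a methyl on the shared core, gives 6.4 in this assay, a gap that lies well beyond the usual scatter.

Compound 3 `CC(C)C(=O)N1N=CCC1c1ccccc1` has not yet been measured. It differs from compound 1 in one place: isopropyl in place of oxan-4-yl on a carbonyl carbon. The leaving group brings one hydrogen-bond acceptor, the entering group brings none.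

Because compound 2 with its carbon-only group on the carbonyl gives 6.4 in this assay, a move in the same direction is expected for compound 3, though smaller, since compound 2 also carries the extra methyl. The step from compound 1 to compound 3 is expected to be an increase of about a number 1.50 log units higher from compound 1 to compound 3 (beyond the scatter) in this assay. Compound 3 is therefore estimated at 4.6, within a range from 3.9 to 5.3.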

Compound 3, distribution coefficient: 4.4
The estimate for compound 3 lay 0.20 log units above the measured number; the measured number falls inside the stated range.
By their numbers in this assay, from the lowest: compound 1; then compound 3; then compound 2.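

The swap on the carbonyl carbon gives a number 1.30 log units higher from compound 1 to compound 3 (beyond the scatter) in this assay, and this is the first pair shown that differs in one place only, so the whole step belongs to this single change. Compound 2 could not show this, since it differs from compound 1 in two places, so this position on the shared core is now shown to move the number by more than the usual scatter. Yet the change is a bundle: oxan-4-yl has 6 heavy atoms, a six-membered ring and 1 hydrogen-bond acceptor, isopropyl has 3 heavy atoms, no ring and no acceptor, and no supporting measurement is available to say which of these differences accounts for the step.

The compounds shown leave open how cyclohexyl would read on this carbonyl carbon, a group that would keep the six-membered ring of oxan-4-yl while replacing its oxygen with carbon and so pull ring and oxygen apart. They also leave open whether the same swap gives a step of similar size on a core carrying the methyl of compound 2.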